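The source may report more compounds than this note shows. Statements on the series, on what has been measured and on what is new or still open speak of the compounds shown alone.

Working notes on the series. In an assay on isolated protein for inhibition of NEDD8-activating enzyme E1 regulatory subunit (Homo sapiens), read by Western blot, with stated times of 10 min and 30 min, tested at 25 uM (a higher number here means more inhibition at the concentration tested (going by the name of the read-out), a lower number less inhibition), compound 1 `CCOC(=O)CNC(=O)c1cccc2nc(OCC)n(Cc3ccc(-c4ccccc4-c4nnn[nH]4)cc3)c12` gives 46.5%, the higher of the two numbers available; its nearest neighbour is compound 2 `CCOc1nc2cccc(C(=O)N[C@H]3CC[C@H](C(=O)OC)CC3)c2n1Cc1ccc(-c2ccccc2-c2nnn[nH]2)cc1`, which in this assay gives 28.6%. Going by the values given here, the only measured step, a number 17.9 percentage points lower from compound 1 to compound 2 (beyond the scatter), replaces the same amide substituent that compound 3 `CCOc1nc2cccc(C(=O)Nc3ccc(OC)cc3)c2n1Cc1ccc(-c2ccccc2-c2nnn[nH]2)cc1` alters: 4-methoxyphenyl in place of (ethoxycarbonyl)methyl on an amide-type nitrogen. That one step is a modest drop beyond the scatter, but it introduces a saturated ring carrying an ester, not an aromatic ring with a methoxy group, so it bears on compound 3 only loosely. With a single step of this kind, the change from compound 1 to compound 3 is expected to be a small loss or none beyond the scatter, here put at a number 8.5 percentage points lower from compound 1 to compound 3 (within the scatter). Compound 3 is therefore estimated at 38% in this assay, with a range of 20% to 56%.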

Compound 3, a percentage reported as inhibition, at one concentration (the size of the read-out at that concentration, not a potency): 25.8%
For compound 3 the middle estimate is 12.2 percentage points above the measured one; the range from low to high includes it.
By their numbers in this assay, from the lowest: compounds 3 and 2 (each within the scatter of the next); then compound 1.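

In this assay the amide-type nitrogen proves sensitive to a second kind of ring: 4-methoxyphenyl in place of (ethoxycarbonyl)methyl gives a number 20.7 percentage points lower from compound 1 to compound 3 (beyond the scatter), so the earlier loss is not confined to the saturated ring carrying an ester. Going by these compounds alone, the two ring-bearing substituents cannot be told apart, with a number 2.8 percentage points lower from compound 2 to compound 3 (within the scatter), and across these three compounds only the open-chain (ethoxycarbonyl)methyl group gives the higher number, with no compound going against that. No supporting evidence is available to explain this result.

The compounds shown do not separate the effect of adding a ring from that of losing the (ethoxycarbonyl)methyl group. A carboxylic acid in place of the ethyl ester, a longer chain between the nitrogen and the ester, or an unsubstituted phenyl ring would bear on that question.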